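The source may hold more compounds than are shown below. What is called first, only, known or untested is meant among the compounds shown, and "the series" means these compounds.

Three compounds have been measured in a functional assay on CHO cells for antagonist activity at sphingosine 1-phosphate receptor 2 (Homo sapiens), read by fluorescence and calcium flux, with a stated time of 3 min; a higher number here means a weaker inhibitor, a lower number a stronger inhibitor:

Compound 1 `Cc1cc(CNC(=O)Nc2cc(Cl)nc(Cl)c2)ncc1-c1cn(C)nc1C`: 300 nM
Compound 2 `CCOc1cc(NC(=O)NCc2cc(C)c(-c3cn(C)nc3C(F)(F)F)nn2)cc(C)n1`: 54000 nM
Compound 3 `Cc1cc(CNC(=O)Nc2cc(OCC(O)CO)nc(C(F)(F)F)c2)nnc1-c1cn(C)nc1C(F)(F)F`: > 6610000 nM, which is a limit of the assay and not a number.

Compound 3 therefore stands at the limit of > 6610000 nM in this assay, at which 1 of the 3 values shown sits, and it is the only one of the three that sits there. Compound 1 and compound 2 both give real numbers, and of these two compound 2 gives the higher value, that is the weaker inhibition, in this assay.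

Compound 4 `Cc1cc(CNC(=O)Nc2cc(OCCO)nc(C(F)(F)F)c2)nnc1-c1cn(C)nc1C(F)(F)F` has not yet been measured. It differs from compound 3 in one place: hydrogen in place of hydroxymethyl on a saturated chain carbon bound to an oxygen on a saturated carbon and a saturated chain carbon. This is a small trimming of a side chain, with no change to the shared core or to the other groups of compound 3. Within the data shown here, there is no measured pair of compounds that makes the same change, so the size of the step can only be guessed. The expectation is a step of modest size toward stronger inhibition, an at least 1.6-fold lower number from compound 3 to compound 4 (0.21 log units; that floor lies within the scatter), since a small change of this kind rarely moves a value far. Compound 4 is thus expected to sit near 4000000 nM, within a range from 400000 nM to 20000000 nM, and it is expected more likely than not to be reported again only as a limit in this assay.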

Compound 4, half-maximal inhibitory concentration: 348000 nM
Estimate against measurement, compound 4: 11-fold (1.06 log units) above, and the stated range ends above it.
By their numbers in this assay, from the lowest: compound 1; then compound 2; then compound 4. At a limit, above all of these: compound 3.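

In this assay, cutting the 2,3-dihydroxypropoxy group back to 2-hydroxyethoxy gives an at least 18-fold lower number from compound 3 to compound 4 (1.27 log units; beyond the scatter), so this side chain is not a place where a small trim goes unnoticed. The step is only a floor on the true size of the change, since compound 3 is held at a limit of the assay and not at a number: the limit of > 6610000 nM in this assay, at which 1 of the 4 values shown sits.

Compound 4 gives a real number at this position, so further changes to this chain can now be compared with a measured value and not only with a limit.

This is a single pair, so it cannot show whether removing the hydroxymethyl would have a similar effect on a different core, such as those of compound 1 or compound 2. It also leaves open what the chain end of compound 4 contributes, which could be tested by replacing its hydroxyl with an amine or a carboxylic acid, or by moving to a longer chain, on the same shared core.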